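The source may report more compounds than this note shows. Statements on the series, on what has been measured and on what is new or still open speak of the compounds shown alone.

Of the compounds shown here, three that share one core have been measured in a functional assay on RAW264.7 cells (Mus musculus) for inhibition, with a stated time of 30 min; on this read-out higher numbers stand for weaker inhibition and lower numbers for stronger inhibition. Compound 1 `C=C1C(=O)OC[C@@H]1CCOC(=O)Nc1ccc(CCCC)cc1` gives 1230 nM in this assay. Compound 2 `C=C1C(=O)OC[C@@H]1CCOC(=O)Nc1ccc(Cl)cc1` gives 1070 nM in this assay. Compound 3 `C=C1C(=O)OC[C@@H]1CCOC(=O)Nc1ccc(CC)cc1` gives 1260 nM in this assay. Compound 3 carries the largest of the three numbers, but only by a hair: the step of a 1.0-fold higher number from compound 1 to compound 3 (0.01 log units; within the scatter) and the step of a 1.2-fold higher number from compound 2 to compound 3 (0.07 log units; within the scatter) both fall inside the scatter of repeated measurements, so on the numbers shown the three compounds cannot be told apart.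

Compound 4 `C=C1C(=O)OC[C@@H]1CCOC(=O)Nc1ccc(OC)cc1` has not yet been measured in this assay. It differs from compound 3 in one place: methoxy in place of ethyl on an aromatic carbon. The two measured steps that touch compound 3 bear on this change, since each also swaps the group on that aromatic carbon or shortens the chain attached to it, and neither moved the number beyond the scatter. The swap from chloro to ethyl and the cut from butyl to ethyl left the read-out essentially where it was. By the same reasoning, the expected step is a 1.1-fold lower number from compound 3 to compound 4 (0.02 log units; within the scatter), with no movement beyond the scatter foreseen in either direction. For compound 4 the estimated value in this assay is 1200 nM, with a range from 600 nM to 2500 nM.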

Compound 4, half-maximal inhibitory concentration: 1090 nM
The estimate for compound 4 lay 1.1-fold (0.04 log units) above the measured number, within the range that was stated.
By their numbers in this assay, from the lowest: compounds 2, 4, 1 and 3 (each within the scatter of the next).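

Compound 4 is the only one of the four with an oxygen on this aromatic carbon, para to a large group, and its methoxy brings one hydrogen-bond acceptor where ethyl has none, yet in this assay this exchange gives only a 1.2-fold lower number from compound 3 to compound 4 (0.06 log units; within the scatter) and stays within the scatter. The comparisons with the other two groups read the same way, with a 1.0-fold higher number from compound 2 to compound 4 (0.01 log units; within the scatter) and a 1.1-fold lower number from compound 1 to compound 4 (0.05 log units; within the scatter) both also within the scatter, so methoxy cannot be told apart from chloro, ethyl or butyl here. Among these four compounds, none goes against the picture that the read-out stays within the scatter whether this position carries a carbon chain, a chlorine atom or a group joined through oxygen.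

On these data alone, whether that holds for a different kind of group at this position, such as an amine, a carboxylic acid or a longer chain, remains open. Nothing available here explains why these four exchanges leave the number within the scatter.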